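This account rests on a few compounds, and the source may have more. Where it says the series, first, only, none or still open, it means among the compounds named here.

Measured so far, in a functional assay on DU-145 cells (Homo sapiens) for antiproliferative activity, read by sulforhodamine B assay, with a stated time of 72 h; a higher number here means a weaker inhibitor, a lower number a stronger inhibitor:

Compound 1 `NC(=S)NNc1nncc2ccccc12` gives 65 nM.
Compound 2 `Cc1cc(NS(=O)(=O)c2ccc(Nc3nncc4ccccc34)cc2)no1` gives 35 nM.
Compound 3 `COc1ccc(NC(=S)NNc2nncc3ccccc23)cc1` gives 25 nM.

All three share the same core and differ in what hangs from it. Among the three numbers, the one for compound 2 sits between the other two, with compound 3 as its nearest neighbour and compound 1 as its furthest; both gaps lie within the usual scatter of repeated measurements, so the three compounds cannot be told apart on these numbers.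

Compound 4 `O=S(=O)(Nc1nccs1)c1ccc(Nc2nncc3ccccc23)cc1` is built from compound 2 by a small swap on the sulfonamide nitrogen: 1,3-thiazol-2-yl in place of 5-methyl-1,2-oxazol-3-yl on a sulfonamide nitrogen. One five-membered aromatic ring with two hetero atoms is exchanged for another of the same kind, and the rest of the molecule is untouched. For the measured compounds named here, no pair of measured compounds here shows what such a swap does in this assay, so the expectation rests on the similarity of the two rings alone.

The step from compound 2 to compound 4 is expected to be small, a 1.1-fold higher number from compound 2 to compound 4 (0.06 log units; within the scatter), in no clear direction and not beyond the scatter. Compound 4 is therefore estimated to give 40 nM in this assay, in a range from 15 nM to 110 nM.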

Compound 4, half-maximal inhibitory concentration: 24 nM
Beside the measured number, compound 4's estimate is 1.7-fold (0.22 log units) above it; the measured number falls inside the stated range.
By their numbers in this assay, from the lowest: compounds 4, 3, 2 and 1 (each within the scatter of the next, the first and the last beyond it).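

In this assay, for the compounds shown here, the exchange of 5-methyl-1,2-oxazol-3-yl for 1,3-thiazol-2-yl on a sulfonamide nitrogen gives a 1.5-fold lower number from compound 2 to compound 4 (0.16 log units; within the scatter) and is the first step that can be read at this position, since the earlier compounds offered no pair differing in one place. One five-membered aromatic ring with two hetero atoms can therefore stand in for the other here without a change that rises above the scatter, even though the oxygen and the methyl group leave and a sulfur enters. This is one pair only, so it shows that this particular exchange is tolerated, not that the position accepts any group, and no measurement at hand offers an explanation for the result.

As far as these compounds go, both rings tried so far are of the same kind, so it remains open what a six-membered ring such as pyridin-2-yl, or a simple methyl group or a plain hydrogen in the same place, would do to the number. From the compounds shown here alone, it is also open whether a ring carrying an amine or a carboxylic acid would stay within the scatter of compound 2 or move clearly away from it.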